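A few compounds are considered here, and "the series" means these few. Any claim that something is new, unique, unknown or untested is made for them only; others in the source may bear on it.

In an ADME assay on a cell-free system (plasma, Homo sapiens) for metabolic stability, read by HPLC (on this read-out higher numbers stand for a longer-lived compound and lower numbers for a shorter-lived compound), compound 1 `CN(/N=N/c1ccc(C#N)cc1)C(=O)CCc1ccc(O)cc1` gives 5.8 h. Compound 2 `COC(=O)c1ccc(/N=N/N(C)C(=O)CCc2cccc(O)c2)cc1` gives 7.8 h, which lies within the scatter of compound 1. Compound 3 `CN(/N=N/c1ccc(C#N)cc1)C(=O)CCCCc1ccc(O)cc1` gives 11.8 h, a higher number than that of compound 1 by a margin beyond the scatter. Compound 4 `CN(/N=N/c1ccc(C(N)=O)cc1)C(=O)CCc1ccc(O)cc1` carries carbamoyl in place of cyano on an aromatic carbon, a swap counted as carbamoyl in place of cyano on an aromatic carbon. Going by the values given here, no two measured compounds differ in one place only, so the data offer no direct measure of such a swap. The estimated step of a 1.0-fold higher number from compound 1 to compound 4 (0.01 log units; within the scatter) is therefore expected to stay within the scatter, with no direction foreseen. Compound 4 is expected at 6 h, with an estimated range of 3 h to 12 h.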

Compound 4, half-life in the plasma assay: 48.5 h
Compound 4: middle estimate off by 8.1-fold (0.91 log units), on the low side; the whole stated range lies below it.
By their numbers in the plasma assay, from the lowest: compounds 1, 2 and 3 (each within the scatter of the next, the first and the last beyond it); then compound 4.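

In the plasma assay, compound 1 gives 5.8 h and compound 4 gives 48.5 h; carbamoyl in place of cyano on an aromatic carbon gives an 8.4-fold higher number from compound 1 to compound 4 (0.92 log units; beyond the scatter), showing that the group at this place can change the half-life. In a physicochemical assay for metabolic stability, read by HPLC, in phosphate buffer, at pH 7.4 (a lower number here means that the compound disappears faster, a higher number that the compound lasts longer), compound 1 gives 76 h and compound 4 gives 118 h; the same swap gives a 1.6-fold higher number from compound 1 to compound 4 (0.19 log units; within the scatter), so the large step appears only in plasma. Nothing available here accounts for this difference. As far as these compounds go, whether a carboxylic acid on this aromatic carbon would match carbamoyl in the plasma assay remains open. So does whether the swap would have a similar effect with the longer chain of compound 3.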